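This account rests on a few compounds, and the source may have more. Where it says the series, first, only, none or still open, it means among the compounds named here.

Compound 1 (`Cc1ccc2nc(NCCS)sc2c1`) – 4040000 nM
Compound 2 (`N=c1sc2ccccc2n1CCSS(=O)(=O)O`) – "nd(insoluble)" (no result reported)

Among the measured compounds shown here, in a functional assay (a higher number here means a weaker inhibitor, a lower number a stronger inhibitor), compound 1 gives 4040000 nM, and this is the only number available, so it cannot be ranked against anything. Compound 2 gave no numerical result ("nd(insoluble)" (no result reported)) and offers no comparison.

The next compound to be tested is compound 3 (`Cc1ccc2nc(S)sc2c1`). In it, sulfanyl stands in place of (2-sulfanylethyl)amino on an aromatic carbon (sulfanyl in place of (2-sulfanylethyl)amino on an aromatic carbon), while the rest of the core of compound 1 stays the same. For the measured compounds named here, no measured pair shows what such a change does in this assay, so any expectation is loose. The step is expected to be moderate and toward stronger inhibition (a 5.1-fold lower number from compound 1 to compound 3 (0.70 log units; beyond the scatter)), resting only on how high compound 1 sits (4040000 nM) on this scale. For compound 3 the estimated value is 800000 nM (expected range 80000 nM to 4000000 nM).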

Compound 3, half-maximal inhibitory concentration: 76700 nM
Beside the measured number, compound 3's estimate is 10-fold (1.02 log units) above it, outside the stated range (below it).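

In this assay, putting sulfanyl in place of (2-sulfanylethyl)amino on the aromatic carbon gives a 53-fold lower number from compound 1 to compound 3 (1.72 log units; beyond the scatter) and so provides the only readable comparison among these compounds. It shows that at this position, next to the ring nitrogen and next to the ring sulfur, the chain of 4 heavy atoms is not required for inhibition: with the rest of the core of compound 1 unchanged, sulfanyl alone gives the stronger inhibitor. No measurement available here accounts for the size of this step.

This single step leaves open whether the loss of the chain or the loss of its nitrogen matters more. It also leaves open how a simple amine, a hydroxyl or a longer chain ending in sulfanyl would compare at this position.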